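The source may report more compounds than this note shows. Statements on the series, on what has been measured and on what is new or still open speak of the compounds shown alone.

In a functional assay on HepG2 cells (Homo sapiens) for cytotoxicity, read by MTT assay, with a stated time of 72 h (on this read-out higher numbers stand for weaker inhibition and lower numbers for stronger inhibition), compound 1 `Nc1ccccc1NC(=O)c1ccc(CNC(=O)c2cc3cccnc3[nH]2)cc1` gives 6100 nM and compound 2 `Nc1ccccc1NC(=O)c1ccc(CNC(=O)c2cc3cnccc3[nH]2)cc1` gives 1700 nM, the lower of the two numbers. Compound 3 `Nc1ccccc1NC(=O)c1ccc(CNC(=O)c2ccc3cncn3c2)cc1` has the same atoms as compound 2, joined differently: a group of 9 heavy atoms (7 carbon, 2 nitrogen; one five-membered aromatic ring with 2 hetero atoms, one six-membered aromatic ring with 1 hetero atom) in place of a group of 9 heavy atoms (7 carbon, 2 nitrogen; one five-membered aromatic ring with 1 hetero atom, one six-membered aromatic ring with 1 hetero atom), on a carbonyl carbon. Among the measured compounds shown here, the one measured step that bears on this is a 3.6-fold lower number from compound 1 to compound 2 (0.55 log units; beyond the scatter), also an exchange of one group for another on a carbonyl carbon. On that single step, a change of similar size is expected in this assay, more likely toward a higher number. The expected change is a 1.5-fold higher number from compound 2 to compound 3 (0.17 log units; within the scatter). For compound 3 the estimated value is 2500 nM, with an expected range from 800 nM to 7000 nM.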

Compound 3, half-maximal inhibitory concentration: 3400 nM
Estimate against measurement, compound 3: 1.4-fold (0.13 log units) below; measured number inside the range.
By their numbers in this assay, from the lowest: compounds 2, 3 and 1 (each within the scatter of the next, the first and the last beyond it).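

In this assay, the group with 0 hydrogen-bond donors and 2 hydrogen-bond acceptors gives a 2.0-fold higher number from compound 2 to compound 3 (0.30 log units; within the scatter) and a 1.8-fold lower number from compound 1 to compound 3 (0.25 log units; within the scatter), both within the scatter. Compound 3 is thus separated from neither earlier compound, although those two lie beyond the scatter of each other, so on this carbonyl carbon the hydrogen-bond donor of the two earlier groups is not shown to be needed for a number in this range. No measurement at hand accounts for this result. The compounds shown leave open how a group carrying an amine or a carboxylic acid would read at this place.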